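This account rests on a few compounds, and the source may have more. Where it says the series, first, only, none or still open, it means among the compounds named here.

Compound 1 `CCCCCCCCCCCCCCNC(=O)[C@H](CO)/N=C/c1cccc(Cl)c1`: 24100 nM
Compound 2 `CCCCCCCCCCCCCCNC(=O)[C@H](CO)/N=C/c1ccc(OC)cc1`: 28100 nM
Compound 3 `CCCCCCCCCCCCCCNC(=O)[C@H](CO)/N=C/c1ccc(Cl)cc1`: 27500 nM

In a functional assay on cells (Homo sapiens) for cytotoxicity, read by MTT assay, with a stated time of 24 h (on this read-out higher numbers stand for weaker inhibition and lower numbers for stronger inhibition), compound 3 gives 27500 nM, the second highest of the three numbers; its nearest neighbour is compound 2 and its furthest is compound 1, both within the scatter. The step to compound 4 `CCCCCCCCCCCCCCNC(=O)[C@H](CO)/N=C/c1cccc(O)c1` is 3-hydroxyphenyl in place of 4-chlorophenyl on a carbon with a double bond to nitrogen. Going by the values given here, two measured steps bear on it: a 1.1-fold higher number from compound 1 to compound 3 (0.06 log units; within the scatter), and a 1.0-fold lower number from compound 2 to compound 3 (0.01 log units; within the scatter). Neither a change of ring position nor a change of substituent on the ring has moved this assay beyond the scatter so far. A hydroxy group has not been tried, but nothing seen here points to a shift. Compound 4 is therefore expected to give about 26000 nM, between 13000 nM and 52000 nM, a step of a 1.1-fold lower number from compound 3 to compound 4 (0.02 log units; within the scatter) that is expected to stay within the scatter.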

Compound 4, half-maximal inhibitory concentration: 32600 nM
The estimate for compound 4 lay 1.3-fold (0.10 log units) below the measured number; measured number inside the range.
By their numbers in this assay, from the lowest: compounds 1, 3, 2 and 4 (each within the scatter of the next).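

In this assay the readings for 3-hydroxyphenyl on a carbon with a double bond to nitrogen show a 1.2-fold higher number from compound 3 to compound 4 (0.07 log units; within the scatter) and a 1.2-fold higher number from compound 2 to compound 4 (0.06 log units; within the scatter) and a 1.4-fold higher number from compound 1 to compound 4 (0.13 log units; within the scatter) with all three within the scatter. The hydrogen-bond donor entering with 3-hydroxyphenyl thus brings no step beyond the scatter at this place, whichever of the three earlier rings it replaces. No supporting evidence is available to explain this result. The compounds shown leave open whether an amine or a carboxylic acid on this ring would move the number beyond the scatter. They also leave open what a pyridine ring would do in its place.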